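Swapping a thiophene for iodine on a nucleoside core

The compounds below may be only part of what the source reports. "The series", "measured", "known", "first", "only" and "open" are said of these compounds alone.

Measured compounds:
compound 1 `COc1ncnc2c1c(-c1ccsc1)cn2[C@@H]1O[C@H](CO)[C@@H](O)[C@H]1O`, 64300 nM
compound 2 `COc1ncnc2c1c(-c1cccs1)cn2[C@@H]1O[C@H](CO)[C@@H](O)[C@H]1O`, 62800 nM
compound 3 `CSc1ncnc2c1c(-c1cccs1)cn2[C@@H]1O[C@H](CO)[C@@H](O)[C@H]1O`, 96900 nM

All three compounds were tested in an ADME assay on BJ cells (Homo sapiens), read by MTT assay, with a stated time of 72 h; on this read-out lower numbers stand for stronger inhibition and higher numbers for weaker inhibition. Compound 2 gives 62800 nM, the lowest of the three numbers, yet the two steps among the measured compounds are a 1.0-fold lower number from compound 1 to compound 2 (0.01 log units; within the scatter) and a 1.5-fold higher number from compound 2 to compound 3 (0.19 log units; within the scatter), so the three compounds cannot be told apart. Compound 4 `COc1ncnc2c1c(I)cn2[C@@H]1O[C@H](CO)[C@@H](O)[C@H]1O` has not yet been measured. It differs from compound 2 in one place: iodo in place of thiophen-2-yl on an aromatic carbon. Neither measured step touches this position in this way: the step from compound 1 to compound 2 swaps one thiophenyl for another, and the step from compound 2 to compound 3 alters the methoxy group, and both stayed within the scatter. There is thus no measured guide to what iodo does here, and no step beyond the scatter is expected in this assay. Compound 4 is therefore estimated at 70000 nM, with a range from 25000 nM to 200000 nM. The step from compound 2 that this estimate implies, a 1.1-fold higher number from compound 2 to compound 4 (0.05 log units; within the scatter), is expected to lie within the scatter.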

Compound 4, half-maximal inhibitory concentration: 91000 nM
Estimate against measurement, compound 4: 1.3-fold (0.11 log units) below; the measured number falls inside the stated range.
By their numbers in this assay, from the lowest: compounds 2, 1, 4 and 3 (each within the scatter of the next).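

In this assay, putting iodo in place of either thiophene leaves the number within the usual scatter (a 1.4-fold higher number from compound 2 to compound 4 (0.16 log units; within the scatter); a 1.4-fold higher number from compound 1 to compound 4 (0.15 log units; within the scatter)). The earlier compounds shown here only swapped one thiophenyl for the other or changed the methoxy group, so they could not show that this aromatic carbon accepts either a whole five-membered aromatic ring or a lone iodine atom with no step that can be told from scatter. No measurement shown offers a reason for this result.

Going by these compounds, it remains open whether a different group on this carbon, such as an amine, a carboxylic acid or a longer carbon chain, would move the number beyond the scatter. On these data alone, it is also open whether iodo would give a similar number with methylsulfanyl in place of methoxy on the shared core.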